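From benzyl to 2-(methylsulfonyl)ethyl on a shared core

This account rests on a few compounds, and the source may have more. Where it says the series, first, only, none or still open, it means among the compounds named here.

In a functional assay on blood (Homo sapiens) for inhibition (on this read-out lower numbers stand for stronger inhibition and higher numbers for weaker inhibition), compound 1, `O=C(O)COc1ccc(OCc2ccc3ccccc3n2)cc1C1(c2ccccc2)CC2CCC1C2`, gives > 3000 nM, which is a limit of the assay and not a number. Compound 2, `c1ccc(COc2ccc(OCc3ccc4ccccc4n3)cc2C2(c3ccccc3)CC3CCC2C3)cc1`, gives > 3000 nM, again only a limit. So far the record reads (the limit of > 3000 nM in this assay, at which 2 of the 2 values shown sit). Among the measured compounds shown here, the one measured step is a step that the two limits leave unreadable from compound 1 to compound 2, and it offers no size to carry forward.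

Compound 3, `CS(=O)(=O)CCOc1ccc(OCc2ccc3ccccc3n2)cc1C1(c2ccccc2)CC2CCC1C2`, has not yet been measured. It differs from compound 2 as follows: (methylsulfonyl)methyl in place of phenyl on a saturated chain carbon bound to an oxygen on an aromatic ring. Put another way, benzyl gives way to 2-(methylsulfonyl)ethyl.

With no readable step to draw on, no definite shift in either direction is expected in this assay, and another limit is a likely result. The expected change is a number no higher from compound 2 to compound 3 (the limit leaves the size open). For compound 3 the estimated value is 3000 nM, with an expected range of 800 nM to 10000 nM.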

Compound 3, half-maximal inhibitory concentration: 114 nM
Compound 3: the middle estimate sits 26-fold (1.42 log units) above what was measured, outside the stated range (below it).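

Placing (methylsulfonyl)methyl in place of phenyl on a saturated chain carbon bound to an oxygen on an aromatic ring gives an at least 26-fold lower number from compound 2 to compound 3 (1.42 log units; beyond the scatter) in this assay, which shows that the value at this position depends on the group it carries. The same group in place of carboxy gives an at least 26-fold lower number from compound 1 to compound 3 (1.42 log units; beyond the scatter), so the change holds against both earlier groups. Compound 3 alone has a number, and the two sizes are minimums, as the other compounds stop at a limit: the limit of > 3000 nM in this assay, at which 2 of the 3 values shown sit.

From the compounds shown here alone, the step between compound 1 and compound 2 cannot be read, so the order of those two compounds stays unknown. Going by these compounds, it also remains open whether the methylsulfonyl group itself is needed, or whether an amide, a hydroxyl or a longer chain ending in methylsulfonyl would give a similar value.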